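The source may hold more compounds than are shown below. What is called first, only, known or untested is meant among the compounds shown, and "the series" means these compounds.

Measured in a functional assay on HeLa cells (Homo sapiens) for antiproliferative activity, with a stated time of 5 days; a higher number here means a weaker inhibitor, a lower number a stronger inhibitor:
- Compound 1 `O=C1C=CC2(C=C1)OCC(=O)N2c1nc(-c2ccc3ncccc3c2)nn1-c1ccccc1`: 110 nM
- Compound 2 `CC1OC2(C=CC(=O)C=C2)N(c2nc(-c3ccc4ccccc4c3)nn2-c2ccccc2)C1=O`: 120 nM
- Compound 3 `O=C1C=CC2(C=C1)OCC(=O)N2c1nc(-c2ccc3c(c2)OCCO3)nn1-c1ccccc1`: 70 nM

Compound 3 stands within the scatter of both compound 1 and compound 2, so these three values do not separate. The next structure is compound 4 `O=C1C=CC2(C=C1)OCC(=O)N2c1nc(-c2ccc3ccccc3c2Br)nn1-c1ccccc1`, and its change from compound 3 is 1-bromonaphthalen-2-yl in place of 2,3-dihydro-1,4-benzodioxin-6-yl on an aromatic carbon. Here 1-bromonaphthalen-2-yl comes in place of 2,3-dihydro-1,4-benzodioxin-6-yl on an aromatic carbon of a five-membered aromatic ring with 3 nitrogen.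

Among the measured compounds shown here, only one measured step bears on this place: a 1.6-fold lower number from compound 1 to compound 3 (0.20 log units; within the scatter), which stays within the scatter. For the measured compounds named here, no measured compound carries a bromine, so the data say nothing directly about that atom, and the range must stay wide. No shift beyond the scatter is therefore expected in this assay, and no direction can be firmly expected. The estimated step is a 1.4-fold higher number from compound 3 to compound 4 (0.15 log units; within the scatter). In this assay compound 4 is estimated at 100 nM, with an expected range from 35 nM to 300 nM.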

Compound 4, half-maximal inhibitory concentration: 290 nM
The estimate for compound 4 lay 2.9-fold (0.46 log units) below the measured number, within the range that was stated.
By their numbers in this assay, from the lowest: compounds 3, 1 and 2 (each within the scatter of the next); then compound 4.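

At the aromatic carbon of the five-membered aromatic ring with 3 nitrogen, the earlier step stayed within the scatter, whereas 1-bromonaphthalen-2-yl gives the first steps there that lie beyond it in this assay: a 4.1-fold higher number from compound 3 to compound 4 (0.62 log units; beyond the scatter) and a 2.6-fold higher number from compound 1 to compound 4 (0.42 log units; beyond the scatter). The group on this carbon can therefore move the number, here upward against both 2,3-dihydro-1,4-benzodioxin-6-yl and quinolin-6-yl, although both steps are modest. No measurement at hand accounts for this shift.

The whole group changes in each step, so the compounds shown leave open how much of the shift belongs to the bromine and how much to the rest of the group. Also open, on these data alone, is how a chlorine, a methoxy group or an amine would read in the place of that bromine.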